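Bromo for fluoro on the second aryl ring

The source may report more compounds than this note shows. Statements on the series, on what has been measured and on what is new or still open speak of the compounds shown alone.

Compound 3 `Nc1sc(-c2ccc(F)cc2)c(-c2ccc(Cl)cc2)c1C(=O)NC1CC1` gives 28000 nM in a functional assay on PC-3 cells (Homo sapiens) for cytotoxicity, read by sulforhodamine B assay, with a stated time of 72 h (a higher number here means a weaker inhibitor, a lower number a stronger inhibitor), the highest of the three numbers: compound 1 `Nc1sc(-c2ccccc2)c(-c2ccc(Cl)cc2)c1C(=O)NC1CC1` gives 17100 nM and compound 2 `Nc1sc(-c2ccc(Cl)cc2)c(-c2ccc(Cl)cc2)c1C(=O)NC1CC1` gives 3680 nM. Compound 4 `Nc1sc(-c2ccc(Br)cc2)c(-c2ccc(Cl)cc2)c1C(=O)NC1CC1` differs from compound 3 by bromo in place of fluoro on an aromatic carbon. Going by the values given here, the steps that bear on this are a 7.6-fold higher number from compound 2 to compound 3 (0.88 log units; beyond the scatter), a 4.6-fold lower number from compound 1 to compound 2 (0.67 log units; beyond the scatter) and a 1.6-fold higher number from compound 1 to compound 3 (0.21 log units; within the scatter). Since bromo, like chloro, sits at the same place where chloro gave the lower number, the number for compound 4 is expected to fall again, by about an 8.0-fold lower number from compound 3 to compound 4 (0.90 log units; beyond the scatter) in this assay. Compound 4 is therefore estimated at 3500 nM, with a range from 1200 nM to 10000 nM.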

Compound 4, half-maximal inhibitory concentration: 37300 nM
Estimate against measurement, compound 4: 11-fold (1.03 log units) below, and the stated range ends below it.
By their numbers in this assay, from the lowest: compound 2; then compounds 1, 3 and 4 (each within the scatter of the next, the first and the last beyond it).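

Bromo at this place does not follow chloro in this assay: the result is a 10-fold higher number from compound 2 to compound 4 (1.01 log units; beyond the scatter) and a 1.3-fold higher number from compound 3 to compound 4 (0.12 log units; within the scatter) so bromo and fluoro cannot be told apart here. Set against hydrogen, the change gives a 2.2-fold higher number from compound 1 to compound 4 (0.34 log units; beyond the scatter) and, among the three halogens shown, only chloro gives a lower number than hydrogen. Nothing available explains why chloro alone stands apart.

The compounds shown leave open whether a methyl, a methoxy or a trifluoromethyl group at this place would match chloro or the other two halogens. They also leave open how an amine or a carboxylic acid there would read.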